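Bromo to 3-aminophenyl on the shared core: expected solubility

The compounds below may be only part of what the source reports. "The series", "measured", "known", "first", "only" and "open" are said of these compounds alone.

Compound 1 `Cc1cc(NCc2ccccn2)n2ncc(Br)c2n1` is measured in a physicochemical assay for solubility, read by HPLC, using the shake flask method, measured as kinetic solubility, with a stated time of 2 h, at pH 7.4 (a higher number here means a more soluble compound, a lower number a less soluble compound), at 89300 nM, the lower of the two numbers obtained, and compound 3 `CCN1CCCC1CNc1cc(C)nc2c(-c3ccccc3)c(C)nn12` stands close by at 172000 nM, within the scatter of this assay. Compound 2 `Cc1cc(NCc2ccc3ccccc3n2)n2nc(C)c(-c3ccccc3)c2n1` is reported only as a limit, < 5000 nM, since the limit of < 5000 nM in this assay, at which 1 of the 3 values shown sits, marks the floor of this assay. Compound 4 `Cc1cc(NCc2ccccn2)n2ncc(-c3cccc(N)c3)c2n1` has not yet been measured; it differs from compound 1 by 3-aminophenyl in place of bromo on an aromatic carbon. Among the measured compounds shown here, no step between two measured compounds matches this change, so the expectation rests on compound 1 alone. A moderate downward step a 2.6-fold lower number from compound 1 to compound 4 (0.41 log units; beyond the scatter) is expected, beyond the usual scatter but not reaching the limit. Compound 4 is therefore estimated at 35000 nM, within a range from 8000 nM to 150000 nM.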

Compound 4, solubility: 160000 nM
Beside the measured number, compound 4's estimate is 4.6-fold (0.66 log units) below it; the measured number lies above the stated range.
By their numbers in this assay, from the lowest: compounds 1, 4 and 3 (each within the scatter of the next). At a limit, below all of these: compound 2.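

In this assay, the exchange of bromo for 3-aminophenyl on this aromatic carbon of the shared core gives a 1.8-fold higher number from compound 1 to compound 4 (0.25 log units; within the scatter). Among the compounds shown here, this is the first step read at this position, and it shows that a six-membered aromatic ring carrying an amine can enter there with no change in solubility beyond the scatter. Nothing shown gives a reason for this result. The compounds shown leave open whether the amine on the phenyl ring matters, and how a carboxylic acid or a longer chain in place of bromo would read.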